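The source may hold more compounds than are shown below. What is called first, only, known or untested is meant among the compounds shown, and "the series" means these compounds.

Measured so far:
compound 1, `C=CCn1c(-c2ccc(OC)cc2C=C)cc2ccccc2c1=O`: 11600 nM
compound 2, `C=CCn1c(-c2cc(OC)c(OC)cc2C=O)cc2ccccc2c1=O`: 67600 nM
compound 3, `COCOCc1cc(OC)c(OC)cc1-c1cc2ccccc2c(=O)[nH]1`: 55200 nM

Of the compounds shown here, three have been tested in a functional assay on SK-MEL-2 cells (Homo sapiens) for cytotoxicity, read by MTT assay, with a stated time of 48 h; a higher number here means a weaker inhibitor, a lower number a stronger inhibitor. Compound 1 gives the lowest number of the three. Compound 3 gives a higher number, and that gap lies beyond the usual scatter of repeated measurements. Compound 2 gives the highest number, and its gap to compound 1 is also beyond the scatter. Compound 4, `C=CCn1c(-c2ccc(OC)cc2COCOC)cc2ccccc2c1=O`, has not yet been measured in this assay. It differs from compound 1 in one place: (methoxymethoxy)methyl in place of vinyl on an aromatic carbon. Within the data shown here, no pair of measured compounds differs by this change alone. Compound 3 carries the (methoxymethoxy)methyl group as well, but it also differs from compound 1 in other places, so its value cannot fix the size of the step on its own. Since compound 3 gives the weaker number, a moderate weakening from compound 1 to compound 4 is expected, at or somewhat beyond the scatter, rather than a gain. For compound 4 the expected step in this assay is a 2.2-fold higher number from compound 1 to compound 4 (0.33 log units; beyond the scatter). For compound 4 an inhibitory concentration of 25000 nM is estimated, with a range from 8000 nM to 80000 nM.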

Compound 4, half-maximal inhibitory concentration: 42600 nM
Beside the measured number, compound 4's estimate is 1.7-fold (0.23 log units) below it; measured number inside the range.
By their numbers in this assay, from the lowest: compound 1; then compounds 4, 3 and 2 (each within the scatter of the next).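

In this assay, the replacement of vinyl by (methoxymethoxy)methyl on this aromatic carbon, ortho to a large group, can now be read by itself, as a 3.7-fold higher number from compound 1 to compound 4 (0.56 log units; beyond the scatter). The earlier compounds shown here could not show this, since they differ from each other in more than one place; this pair shows that the number at this position depends on the group it carries, with vinyl, the smaller group with no hydrogen-bond acceptors, giving the lower number of the two. No measurement is available that accounts for the size of this step.

The compounds shown leave open how an ethyl, a hydroxymethyl or an aminomethyl group would stand at this carbon, so it remains unsettled whether the step follows the loss of the double bond, the added heavy atoms or the two oxygen atoms of the entering group. They also leave open whether the same replacement would give a step of similar size when the shared core carries different groups elsewhere.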